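This account rests on a few compounds, and the source may have more. Where it says the series, first, only, none or still open, it means among the compounds named here.

Measured in a functional assay on MCF7 cells (Homo sapiens) for cytotoxicity, read by MTT assay, with a stated time of 96 h; on this read-out higher numbers stand for weaker inhibition and lower numbers for stronger inhibition:
- Compound 1 `COc1cc(C(=O)c2cn(-c3cccc(C)c3)cc2-c2cccc(N)c2)cc(OC)c1OC`: 130 nM
- Compound 2 `COc1cc(C(=O)c2cn(-c3ccc(C)cc3)cc2-c2ccccc2[N+](=O)[O-])cc(OC)c1OC`: 65 nM
- Compound 3 `COc1cc(C(=O)c2cn(-c3ccc(C)cc3)cc2-c2ccc([N+](=O)[O-])cc2)cc(OC)c1OC`: 200 nM

Compound 3 lies within the scatter of compound 1, while compound 2 lies lower, beyond the scatter. Compound 4 `COc1cc(C(=O)c2cn(-c3ccc(C)cc3)cc2-c2cccc(N)c2)cc(OC)c1OC` has 3-aminophenyl in place of 4-nitrophenyl on an aromatic carbon. Within the data shown here, the only measured step at this place, a 3.1-fold higher number from compound 2 to compound 3 (0.49 log units; beyond the scatter), is modest and exchanges one nitrophenyl for another. Compound 1 also carries 3-aminophenyl and gives 130 nM, which leans the expectation towards a lower number. In this assay, no step beyond the scatter is firmly expected. The expected step is a 1.8-fold lower number from compound 3 to compound 4 (0.26 log units; within the scatter). Compound 4 is estimated at 110 nM, with an expected range of 40 nM to 300 nM.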

Compound 4, half-maximal inhibitory concentration: 53 nM
Estimate against measurement, compound 4: 2.1-fold (0.32 log units) above; the range from low to high includes it.
By their numbers in this assay, from the lowest: compounds 4, 2, 1 and 3 (each within the scatter of the next, the first and the last beyond it).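

In this assay the change to 3-aminophenyl from 4-nitrophenyl on this aromatic carbon gives a 3.8-fold lower number from compound 3 to compound 4 (0.58 log units; beyond the scatter) and reaches beyond the scatter, whereas the change from 2-nitrophenyl gives a 1.2-fold lower number from compound 2 to compound 4 (0.09 log units; within the scatter) and stays within it. With 3-aminophenyl held on this carbon, 4-methylphenyl in place of 3-methylphenyl on the aromatic nitrogen gives a 2.5-fold lower number from compound 1 to compound 4 (0.39 log units; beyond the scatter) and shows that a second place on the shared core also moves the number. No evidence at hand accounts for these steps.

Still open, as far as these compounds go, is how 3-nitrophenyl or 3-hydroxyphenyl would read at this carbon. Until then, the change of group and the change of its ring position stay tied together in the step from 4-nitrophenyl.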